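The source may report more compounds than this note shows. Statements on the series, on what has been measured and on what is new or still open speak of the compounds shown alone.

Of the compounds shown here, three have been measured in an assay on cells for inhibition of Palmitoleoyl-protein carboxylesterase NOTUM variant C330S (Homo sapiens), read by fluorescence, with a stated time of 40 min; on this read-out lower numbers stand for stronger inhibition and higher numbers for weaker inhibition. Compound 1 `Cc1cc(C(=O)O)c(C)n1-c1cccc(Cl)c1` gives 430 nM. Compound 2 `Cc1cc(C(=O)O)c(C)n1-c1cccc(C2CC2)c1` gives 580 nM in this assay; it differs from compound 1 by cyclopropyl in place of chloro on an aromatic carbon, and the step is a 1.3-fold higher number from compound 1 to compound 2 (0.13 log units; within the scatter). Compound 3 `Cc1cc(C(=O)O)c(C)n1-c1cccc(Cl)c1F` gives 380 nM in this assay; it differs from compound 1 by fluoro in place of hydrogen on an aromatic carbon, which is the difference between the two cores, and the step is a 1.1-fold lower number from compound 1 to compound 3 (0.05 log units; within the scatter). Compound 4 `Cc1cc(C(=O)O)c(C)n1-c1cccc(C2CC2)c1F` has not yet been measured in this assay. It differs from compound 3 by cyclopropyl in place of chloro on an aromatic carbon. Among the compounds with values here, this is the same kind of change as the one from compound 1 to compound 2, though the place now is ortho to a fluoro group, which the earlier place was not. Because the earlier change made a step of a 1.3-fold higher number from compound 1 to compound 2 (0.13 log units; within the scatter), the step expected for compound 4 is a 1.3-fold higher number from compound 3 to compound 4 (0.12 log units; within the scatter). The estimate for compound 4 in this assay is therefore 500 nM, with an expected range from 250 nM to 1000 nM.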

Compound 4, half-maximal inhibitory concentration: 200 nM
Compound 4: middle estimate off by 2.5-fold (0.40 log units), on the high side, outside the stated range (below it).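

In this assay, cyclopropyl in place of chloro on the core of compound 3 gives a 1.9-fold lower number from compound 3 to compound 4 (0.28 log units; within the scatter), and set beside the same change on the core of compound 1, the two steps do not separate: the same change on two cores in this assay, a 1.3-fold higher number (0.13 log units; within the scatter) from compound 1 to compound 2 and a 1.9-fold lower number (0.28 log units; within the scatter) from compound 3 to compound 4, 2.6-fold (0.41 log units) apart, within the scatter of two such steps. Fluoro in place of hydrogen with cyclopropyl present gives a 2.9-fold lower number from compound 2 to compound 4 (0.46 log units; beyond the scatter), the only new step beyond the scatter, yet it too does not separate from the same change with chloro present: the same change on two cores in this assay, a 1.1-fold lower number (0.05 log units; within the scatter) from compound 1 to compound 3 and a 2.9-fold lower number (0.46 log units; beyond the scatter) from compound 2 to compound 4, 2.6-fold (0.41 log units) apart, within the scatter of two such steps. Within the data shown here, the data are therefore compatible with each change carrying from one core to the other, but with only one pair of steps per change, they do not establish that it carries, nor do they show whether the two changes act independently.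

The compounds shown leave open whether this holds for other groups on that aromatic carbon, such as methoxy, nitrile or an amine. They also leave open how an amide in place of the carboxylic acid would behave on either core.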